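Cytotoxicity and a Fluoro Added to a Benzyl Ring

This account rests on a few compounds, and the source may have more. Where it says the series, first, only, none or still open, it means among the compounds named here.

Three compounds were tested in an ADME assay on HOS cells (Homo sapiens) for cytotoxicity; on this read-out lower numbers stand for stronger inhibition and higher numbers for weaker inhibition:

Compound 1, `O=C1c2c(ccc(O)c2O)CN1Cc1cccc(F)c1`, gives 8600 nM.
Compound 2, `O=C1c2c(ccc(O)c2O)CN1Cc1cc(F)ccc1F`, gives 13400 nM.
Compound 3, `O=C1c2ccc(O)c(O)c2C(=O)N1Cc1ccc(F)c(Cl)c1`, gives 9540 nM.

Compound 1 and compound 2 share a core and differ in one place: fluoro in place of hydrogen on an aromatic carbon. This change made a step of a 1.6-fold higher number from compound 1 to compound 2 (0.19 log units; within the scatter) in this assay, so the two numbers cannot be told apart. Compound 3 and compound 1 sit on different cores; the difference between the two cores is not broken down here, and their values in this assay are within the scatter of each other.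

Compound 4, `O=C1c2ccc(O)c(O)c2C(=O)N1Cc1cc(Cl)c(F)cc1F`, has not yet been measured. It differs from compound 3 by fluoro in place of hydrogen on an aromatic carbon. Going by the values given here, this is the same kind of change as the one from compound 1 to compound 2, but its surroundings are not identical: here the entering fluoro stands meta to a fluoro group and para to a chloro group, whereas in compound 2 it stood para to a fluoro group. The expected step from compound 3 to compound 4 in this assay is therefore a 1.3-fold higher number from compound 3 to compound 4 (0.10 log units; within the scatter), which rests on the small step seen from compound 1 to compound 2, a 1.6-fold higher number from compound 1 to compound 2 (0.19 log units; within the scatter). Compound 4 is estimated to give 12000 nM, expected to fall between 6000 nM and 25000 nM.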

Compound 4, half-maximal inhibitory concentration: 13700 nM
The estimate for compound 4 lay 1.1-fold (0.06 log units) below the measured number, within the range that was stated.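

In this assay, putting a fluoro in place of hydrogen on an aromatic carbon of compound 3 gives a 1.4-fold higher number from compound 3 to compound 4 (0.16 log units; within the scatter). Set beside the earlier case, the two steps agree: the same change on two cores in this assay, a 1.6-fold higher number (0.19 log units; within the scatter) from compound 1 to compound 2 and a 1.4-fold higher number (0.16 log units; within the scatter) from compound 3 to compound 4, 1.1-fold (0.04 log units) apart, within the scatter of two such steps. This shows that the change behaves alike on these two cores, in the plain sense that on neither core can the number with the added fluoro be told apart from the number without it, but it does not show a real shift that travels from one core to the other, and two pairs cannot establish a rule for the whole series.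

The compounds shown leave open whether a group other than fluoro or chloro on the benzyl ring, such as a methoxy group, an amine or a carboxylic acid, would give a step beyond the scatter. They also leave open whether the agreement between the two cores would hold for a change large enough to be read clearly.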